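The source may hold more compounds than are shown below. What is called first, only, known or untested is meant among the compounds shown, and "the series" means these compounds.

Values measured in a functional assay on L1210 cells (Mus musculus) for inhibition; on this read-out higher numbers stand for weaker inhibition and lower numbers for stronger inhibition:

- Compound 1 `O=C1CCCCC/C1=C\c1cccc(F)c1`: 382000 nM
- Compound 2 `O=C1CCCCC/C1=C\c1cccc(Br)c1`: 246000 nM
- Compound 3 `COc1cccc(/C=C2\CCCCCC2=O)c1`: 283000 nM

Compound 3, at 283000 nM, lies within the scatter of both other compounds, so these three values cannot be ranked. The next compound to consider is compound 4 `O=C1CCCCC/C1=C\c1cccc([N+](=O)[O-])c1`, which has nitro in place of methoxy on an aromatic carbon.

Three measured swaps on this same aromatic carbon bear on the change: a 1.6-fold lower number from compound 1 to compound 2 (0.19 log units; within the scatter), a 1.3-fold lower number from compound 1 to compound 3 (0.13 log units; within the scatter) and a 1.2-fold higher number from compound 2 to compound 3 (0.06 log units; within the scatter). All three are small, and none goes beyond the scatter. Nitro itself has not yet been measured in this set, so the evidence is indirect and leaves some room for surprise. Even so, no step beyond the scatter is expected in this assay, in either direction. The estimated step is a 1.0-fold lower number from compound 3 to compound 4 (0.02 log units; within the scatter). The expected value for compound 4 is 270000 nM, with an estimated range of 130000 nM to 500000 nM.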

Compound 4, half-maximal inhibitory concentration: 162000 nM
For compound 4 the middle estimate is 1.7-fold (0.22 log units) above the measured one; the range from low to high includes it.
By their numbers in this assay, from the lowest: compounds 4, 2, 3 and 1 (each within the scatter of the next, the first and the last beyond it).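

In this assay, among the compounds shown here, nitro gives the first step at this aromatic carbon that goes beyond the scatter, a modest one (a 2.4-fold lower number from compound 1 to compound 4 (0.37 log units; beyond the scatter)). The same group cannot be separated from methoxy (a 1.7-fold lower number from compound 3 to compound 4 (0.24 log units; within the scatter)) or from bromo (a 1.5-fold lower number from compound 2 to compound 4 (0.18 log units; within the scatter)), so among these swaps only nitro and fluoro can be told apart. Nothing available here explains that difference.

As far as these compounds go, whether a group of another kind, such as an amine or a carboxylic acid, on this aromatic carbon would give a larger step remains open. For the compounds shown here, it is also open whether nitro and fluoro would differ in the same way at another place on the ring, or on a core other than the one these compounds share.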